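Pyridin-4-yl in place of 3-cyano-4-fluorophenyl

A few compounds are considered here, and "the series" means these few. Any claim that something is new, unique, unknown or untested is made for them only; others in the source may bear on it.

Compound 1 `N#Cc1cc(-c2nc(C(c3ccc(F)cc3)c3ccc(F)cc3)sc2CC(=O)O)ccc1F`: 80%
Compound 2 `CCC(c1ccccc1)c1nc(-c2ccc(Cl)cc2)c(CC(=O)O)s1`: 50%
Compound 3 `COc1ccc(OC)c(-c2nc(C(c3ccccc3)c3ccccc3)sc2CC(=O)O)c1`: 80%

Of the compounds shown here, three with a shared core have been measured in an in vitro functional assay on HEK285-7 cells for antagonist activity at prostaglandin D2 receptor 2 (Homo sapiens), read by BRET and beta-arrestin recruitment; a lower number here means a smaller maximal response, a higher number a larger maximal response. Compound 1 gives 80%, level with compound 3 at the digits shown, and together these two stand highest of the three numbers. Compound 2 gives 50%, a number that lies beyond the scatter below compound 1.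

Compound 4 `O=C(O)Cc1sc(C(c2ccc(F)cc2)c2ccc(F)cc2)nc1-c1ccncc1` has not yet been measured. It differs from compound 1 in one place:

pyridin-4-yl in place of 3-cyano-4-fluorophenyl on an aromatic carbon

Among the measured compounds shown here, no step between measured compounds isolates a change of this kind, so the direction is uncertain. Compound 4 is expected to give 70%, with a range from 45% to 95%. The step of a number 10 percentage points lower from compound 1 to compound 4 (within the scatter) is estimated to be small, downward or none beyond the scatter.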

Compound 4, largest response reached (reported as efficacy), in percent of the reference or control that the assay uses: 80%
For compound 4 the middle estimate is 10 percentage points below the measured one; measured number inside the range.
By their numbers in this assay, from the lowest: compound 2; then compounds 1, 3 and 4 (each within the scatter of the next).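

In this assay, pyridin-4-yl in place of 3-cyano-4-fluorophenyl gives no change at the digits printed from compound 1 to compound 4 (within the scatter). Among the compounds shown here, this is the first step to isolate this position, and it shows that the nitrile and the fluorine can both go, along with the carbon-only ring, without a shift beyond the scatter. No evidence here accounts for this result.

The compounds shown leave open whether an amine or a longer chain would be accepted on this aromatic carbon. They also leave open whether the same change would hold with another large group on the core.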